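Trifluoromethoxy in Place of Fluoro on an Inactive Scaffold

A few compounds are considered here, and "the series" means these few. Any claim that something is new, unique, unknown or untested is made for them only; others in the source may bear on it.

Compound 1 `Cc1cc(Cl)ccc1OCc1nnc(-c2ccccc2F)o1` gives > 100000 nM, a limit of the assay.
Compound 2 `Cc1cc(Cl)ccc1OCc1nnc(-c2cccc(F)c2)o1` gives > 100000 nM, also a limit of the assay.

In an ADME assay on cells for inhibition of anoctamin-2 (Homo sapiens), read by fluorescence, with a stated time of 20 min (a lower number here means a stronger inhibitor, a higher number a weaker inhibitor), compound 1 stands only at a limit, > 100000 nM, and not at a number. Compound 2 sits at the same kind of limit, > 100000 nM. Among the compounds with values here, the one measured step, a step that the two limits leave unreadable from compound 1 to compound 2, gives no readable size because both of its ends rest on (the limit of > 100000 nM in this assay, at which 2 of the 2 values shown sit). So the two measured compounds show only that neither reaches measurable inhibition within the range of this assay.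

Compound 3 `Cc1cc(Cl)ccc1OCc1nnc(-c2ccccc2OC(F)(F)F)o1` differs from compound 1 in one place: trifluoromethoxy in place of fluoro on an aromatic carbon. Within the data shown here, no measured step covers this change, and the single step that exists is unreadable, so nothing among the measured compounds points toward stronger or weaker inhibition for compound 3. The most defensible expectation is therefore that compound 3 behaves like compound 1, with an expected step of a number no higher from compound 1 to compound 3 (the limit leaves the size open) in this assay. Compound 3 is estimated at 100000 nM, with a range from 20000 nM to 300000 nM, most likely reported again as a limit.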

Compound 3, half-maximal inhibitory concentration: "not active" (no number reported)
The entry for compound 3 holds no number, and the estimate cannot be compared.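

In this assay, within the data shown here, compound 3 is reported as not active, with no number, so no step from compound 1 to compound 3 can be read, and compound 1 itself stands only at a limit: the limit of > 100000 nM in this assay, at which 2 of the 3 values shown sit.

The compounds shown leave open whether trifluoromethoxy in place of fluoro changes inhibition at all, and which change to the shared core would give a measurable value.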